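Exchanging the Side Chain of Compound 3

The compounds below may be only part of what the source reports. "The series", "measured", "known", "first", "only" and "open" are said of these compounds alone.

Compound 1 `Nc1ccc(-c2cc(=O)c3c(N)c(F)c(Cl)c(F)c3o2)cc1F` carries a chloro group on its core and gives 210 nM in a functional assay on MCF7 cells (Homo sapiens) for cytotoxicity, read by neutral red uptake, with a stated time of 3 days; a lower number here means a stronger inhibitor, a higher number a weaker inhibitor. Replacing that chloro with carboxy gives compound 2 `Nc1ccc(-c2cc(=O)c3c(N)c(F)c(C(=O)O)c(F)c3o2)cc1F`, and in this assay compound 2 reaches only the limit > 10000 nM. Replacing the chloro with (3-(dimethylamino)propoxy)methyl gives compound 3 `CN(C)CCCOCc1c(F)c(N)c2c(=O)cc(-c3ccc(N)c(F)c3)oc2c1F`, and in this assay compound 3 likewise reaches only the limit > 10000 nM. Both changes weakened inhibition strongly: an at least 47-fold higher number from compound 1 to compound 2 (1.67 log units; beyond the scatter) and an at least 47-fold higher number from compound 1 to compound 3 (1.67 log units; beyond the scatter), while the step that the two limits leave unreadable from compound 2 to compound 3. Compound 3 thus stands at the same limit as compound 2 (the limit of > 10000 nM in this assay, at which 2 of the 3 values shown sit). Compound 4 `CCCCCC(=O)NCc1c(F)c(N)c2c(=O)cc(-c3ccc(N)c(F)c3)oc2c1F` differs from compound 3 in one place: (pentylcarbonyl)amino in place of 3-(dimethylamino)propoxy on a saturated chain carbon bound to an aromatic carbon. Within the data shown here, no measured pair separates two side chains of this kind at that carbon. Since the steps of an at least 47-fold higher number from compound 1 to compound 2 (1.67 log units; beyond the scatter) and an at least 47-fold higher number from compound 1 to compound 3 (1.67 log units; beyond the scatter) both ended at a limit, compound 4 is expected to stay near that limit as well, and the step that the limit leaves unreadable from compound 3 to compound 4 is expected not to be readable. The estimate for compound 4 in this assay is 12000 nM, within 3000 nM to 40000 nM.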

Compound 4, half-maximal inhibitory concentration: 340 nM
Estimate against measurement, compound 4: 35-fold (1.55 log units) above; the whole stated range lies above it.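

The side chain on the saturated chain carbon decides the outcome in this assay, as (pentylcarbonyl)amino in place of 3-(dimethylamino)propoxy gives an at least 29-fold lower number from compound 3 to compound 4 (1.46 log units; beyond the scatter). The ((pentylcarbonyl)amino)methyl group in place of carboxy gives an at least 29-fold lower number from compound 2 to compound 4 (1.46 log units; beyond the scatter), while in place of chloro it gives a 1.6-fold higher number from compound 1 to compound 4 (0.21 log units; within the scatter), so this side chain and the chloro group cannot be told apart here, and a substituent at this position need not end at a limit. The values of compound 2 and compound 3 are limits of the assay, not numbers: the limit of > 10000 nM in this assay, at which 2 of the 4 values shown sit.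

The compounds shown leave open whether the step to compound 4 turns on the amide, on the pentyl chain or on the loss of the dimethylamino group. An acetyl amide, a free amine on that carbon or a simple alkyl ether at the same place would separate these parts.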